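The compounds below may be only part of what the source reports. "The series", "measured", "known", "first", "only" and "open" are said of these compounds alone.

Compound 1 `CCCCN(CC)c1nc(C)nc2c1ncn2-c1ccc(C(C)C)cc1Br` gives 4.3 nM in an in vitro assay on 293-EBNA cells for binding affinity to corticotropin-releasing factor receptor 1 (Homo sapiens); on this read-out higher numbers stand for weaker inhibition and lower numbers for stronger inhibition. Compound 2 `CCCCN(CC)c1nc(C)nc2c1nc(C)n2-c1ccc(C(C)C)cc1Br` gives 0.9 nM in this assay; the change from compound 1 is methyl in place of hydrogen on an aromatic carbon and the step is a 4.8-fold lower number from compound 1 to compound 2 (0.68 log units; beyond the scatter). Compound 3 `CCCCN(CC)c1nc(C)nc2c1ncn2-c1c(Cl)cc(OC)cc1OC` gives 5.2 nM in this assay; the difference between its core and the core of compound 1 is not broken down here, and the two values lie within the scatter of each other. Compound 4 `CCCCN(CC)c1nc(C)nc2c1nc(C)n2-c1c(Cl)cc(OC)cc1OC` carries the same change on the core of compound 3, (methyl in place of hydrogen on an aromatic carbon), with the place described in the same words as for compound 2. Within the data shown here, the step to compound 4 is expected to be of the same order as the one already seen, because a 4.8-fold lower number from compound 1 to compound 2 (0.68 log units; beyond the scatter) is the single precedent. The expected step is a 4.3-fold lower number from compound 3 to compound 4 (0.64 log units; beyond the scatter). Compound 4 is accordingly estimated at 1.2 nM in this assay, between 0.5 nM and 3 nM.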

Compound 4, inhibition constant: 3.5 nM
Compound 4: the middle estimate sits 2.9-fold (0.46 log units) below what was measured; measured number above the stated range.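

In this assay, methyl in place of hydrogen on an aromatic carbon gives a 1.5-fold lower number from compound 3 to compound 4 (0.17 log units; within the scatter), so the step seen on the core of compound 1 does not carry over at the same size to the core of compound 3. Among these compounds, the two steps differ: the same change on two cores in this assay, a 4.8-fold lower number (0.68 log units; beyond the scatter) from compound 1 to compound 2 and a 1.5-fold lower number (0.17 log units; within the scatter) from compound 3 to compound 4, 3.2-fold (0.51 log units) apart, beyond the scatter of two such steps With only two pairs, this shows that the size of the step depends on the core, but not which part of the difference between the two cores decides it.

Still open, on these data alone, is how a trifluoromethyl group or an amine at this place would behave on either core. Also open, as far as these compounds go, is whether a third core would give a step closer to that of compound 2 or that of compound 4.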